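The compounds below may be only part of what the source reports. "The series", "measured", "known", "first", "only" and "open" are said of these compounds alone.

Measured so far in a functional assay on HT-29 cells (Homo sapiens) for cytotoxicity, read by MTT assay, with a stated time of 72 h; a higher number here means a weaker inhibitor, a lower number a stronger inhibitor:

- compound 1, `CN(C)CCn1cnnc1-c1cc(Oc2ccc(NC(=O)N/N=C/c3ccccc3)cc2F)ccn1`, gives 1120 nM
- compound 2, `CN(C)CCn1cnnc1-c1cc(Oc2ccc(NC(=O)N/N=C/c3ccc(O)cc3)cc2F)ccn1`, gives 1920 nM

Among the measured compounds shown here, compound 2 holds the highest of these two numbers, but the single step that reaches it, a 1.7-fold higher number from compound 1 to compound 2 (0.23 log units; within the scatter), lies within the scatter, so the two compounds cannot be told apart on these data. Compound 3, `CN(C)CCn1cnnc1-c1cc(Oc2ccc(NC(=O)N/N=C/c3ccc(F)cc3Cl)cc2F)ccn1`, has not yet been measured. Relative to compound 2 it carries 2-chloro-4-fluorophenyl in place of 4-hydroxyphenyl on a carbon with a double bond to nitrogen. For the measured compounds named here, only one measured step bears on this change, and only in part: the step from compound 1 to compound 2 shows that adding a hydroxy group to the aromatic ring on that carbon left the number within the scatter, so taking the hydroxy away again would be expected to do little. What the chlorine and fluorine that enter in compound 3 add on top of that is not covered by any measured pair, so the expectation stays near the two measured numbers with a wide range. Compound 3 is therefore expected to come out at about 1300 nM, between 400 nM and 4000 nM, a step of a 1.5-fold lower number from compound 2 to compound 3 (0.17 log units; within the scatter) that is not expected to go beyond the scatter.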

Compound 3, half-maximal inhibitory concentration: 510 nM
Compound 3: middle estimate off by 2.5-fold (0.41 log units), on the high side, and the stated range covers the measured number.
By their numbers in this assay, from the lowest: compound 3; then compounds 1 and 2 (each within the scatter of the next).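

In this assay the aromatic ring on the carbon with a double bond to nitrogen now proves able to move the number beyond the scatter, which the earlier hydroxy change did not show. Putting 2-chloro-4-fluorophenyl in place of 4-hydroxyphenyl produces a 3.8-fold lower number from compound 2 to compound 3 (0.58 log units; beyond the scatter) and putting the same group in place of plain phenyl produces a 2.2-fold lower number from compound 1 to compound 3 (0.34 log units; beyond the scatter) in the direction of a stronger inhibitor, so the modest gain does not depend only on losing the hydroxy group. No measurement here explains why this ring change lowers the number.

The chlorine and the fluorine enter together, so the compounds shown cannot say whether one of them accounts for most of the step or whether the two are needed as a pair. Also open, as far as these compounds go, is how this ring would behave with only one of those halogens, or with a different group such as methoxy, a nitrile or an amine, and whether any such change could lower the number further.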